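The compounds below may be only part of what the source reports. "The series", "measured", "known", "first", "only" and "open" are said of these compounds alone.

Working notes on the series. Compound 2 `Cc1ccc(-c2nc3ccccc3s2)cc1NC(=O)c1cnccc1Cl` has been tested in an ADME assay on HepG2 cells (Homo sapiens) for inhibition, with a stated time of 72 h; a higher number here means that more compound is needed for the effect, a lower number that less compound is needed. In this assay compound 2 gives > 25000 nM, which is a limit of the assay and not a number. Compound 1 `C=C(C)C(=O)Nc1cccc(-c2nc3ccccc3s2)c1` shares the core. In this assay compound 1 gives > 25000 nM, likewise a limit. Among the measured compounds shown here, the two values shown both sit at the limit of > 25000 nM in this assay, at which 2 of the 2 values shown sit, no step between measured compounds is available, and so compound 2 stands at the limit with the other measured compound beside it; no ordering of the two can be drawn.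

Compound 3 `O=C(Nc1cc(-c2nc3ccccc3s2)ccc1F)c1cnccc1Cl` is the next compound to be measured in this assay. It differs from compound 2 by fluoro in place of methyl on an aromatic carbon. For the measured compounds named here, no measured step covers a change of this kind here, and both values shown are limits, so no step beyond the scatter is expected in either direction in this assay. Compound 3 is expected at 30000 nM, with a range from 10000 nM to 100000 nM. The expected step is a step that the limit leaves unreadable from compound 2 to compound 3. Compound 3 is expected most likely to be reported only as a limit as well.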

Compound 3, half-maximal effective concentration: > 25000 nM
Compound 3: only a limit was reported; the forecaster's own chance of this, stated with the estimate: 85%; the middle value lies beyond the limit too.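

In this assay compound 3 gives > 25000 nM, a limit of the assay and not a number. No step can be read from compound 2 to compound 3 because both sit at the same limit: the limit of > 25000 nM in this assay, at which 3 of the 3 values shown sit. The compounds shown leave open whether fluoro in place of methyl on an aromatic carbon changes the concentration needed at all.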